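Shifting a Chlorine on the Amide-Nitrogen Phenyl

A few compounds are considered here, and "the series" means these few. Any claim that something is new, unique, unknown or untested is made for them only; others in the source may bear on it.

Measured compounds:
compound 1, `O=C1CC(c2nc(-c3ccccc3)no2)CN1c1ccccc1`: 350 nM
compound 2, `O=C1CC(c2nc(-c3cccc(Cl)c3)no2)CN1c1cccc(Cl)c1`: > 10000 nM
compound 3, `Cc1ccc(N2CC(c3nc(-c4cccc(F)c4)no3)CC2=O)cc1`: 1200 nM

All three compounds share one core and were tested in an in vitro functional assay on HEK293-A cells for positive allosteric modulation of metabotropic glutamate receptor 5 (Homo sapiens), read by FLIPR and calcium flux; on this read-out lower numbers stand for an effect already at smaller amounts and higher numbers for an effect only at larger amounts of compound. Compound 1 gives 350 nM and compound 3 gives 1200 nM. For compound 2 the assay returns only a limit, > 10000 nM, and not a number. Compound 2 thus sits at the limit of > 10000 nM in this assay, at which 1 of the 3 values shown sits. Compound 4, `O=C1CC(c2nc(-c3cccc(Cl)c3)no2)CN1c1ccc(Cl)cc1`, has not yet been measured. It differs from compound 2 by 4-chlorophenyl in place of 3-chlorophenyl on an amide-type nitrogen in a ring. Within the data shown here, no measured pair of compounds differs in exactly this way, so there is no directly comparable step. Among the measured compounds shown here, the only guide is that compound 3, which also carries a substituted phenyl on the amide-type nitrogen, gives 1200 nM, a numerical value rather than a limit. Since compound 2 is known only as a limit, the step of an at least 4.0-fold lower number from compound 2 to compound 4 (0.60 log units; beyond the scatter) is expected to run toward an effect at smaller amounts, though its size is uncertain. Compound 4 is estimated at 2500 nM, most likely between 600 nM and 10000 nM.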

Compound 4, half-maximal effective concentration: 140 nM
Estimate against measurement, compound 4: 18-fold (1.25 log units) above; the measured number lies below the stated range.
By their numbers in this assay, from the lowest: compound 4; then compound 1; then compound 3. At a limit, above all of these: compound 2.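

With the same atoms in both compounds, putting 4-chlorophenyl in place of 3-chlorophenyl on the amide-type nitrogen gives an at least 71-fold lower number from compound 2 to compound 4 (1.85 log units; beyond the scatter) in this assay. Among these compounds, this shows that the read-out at this position depends strongly on where the chlorine sits on the phenyl, something the earlier compounds could not show because none of them formed a pair differing in one place only. Compound 2 is known only as a limit, so the full size of the step stays unknown: the limit of > 10000 nM in this assay, at which 1 of the 4 values shown sits.

Still open, on these data alone, is whether a 2-chlorophenyl, a 4-methoxyphenyl or a 4-aminophenyl in the same place would fit this picture. Also open, as far as these compounds go, is whether the step would keep its size if the other 3-chlorophenyl on the shared core were replaced by a different group.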